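The source may hold more compounds than are shown below. What is called first, only, known or untested is meant among the compounds shown, and "the series" means these compounds.

Measured so far:
compound 1, `C[S+]([O-])c1ccc(-c2nc3ccc(Cl)cc3nc2-c2ccc(Cl)cc2)cc1` — 1580 nM
compound 2, `CS(=O)(=O)c1ccc(-c2nc3ccc(Cl)cc3nc2-c2ccc(Cl)cc2)cc1` — 2000 nM
compound 3, `COc1ccc2nc(NC3CCCCC3)c(S(C)(=O)=O)nc2c1` — 12600 nM

All three compounds were tested in an ADME assay on HepG2 cells (Homo sapiens) for cytotoxicity, read by CellTiter-Glo, with a stated time of 48 h; a higher number here means that more compound is tolerated, a lower number that less compound is tolerated. Compound 1 differs from compound 2 by a group of 3 heavy atoms (1 carbon, 1 oxygen, 1 sulfur; no ring) in place of a group of 4 heavy atoms (1 carbon, 2 oxygen, 1 sulfur; no ring), on an aromatic carbon; the step across that change is a 1.3-fold lower number from compound 2 to compound 1 (0.10 log units; within the scatter). Compound 3 gives the highest of the three numbers; its distance from compound 2 and its distance from compound 1 both lie beyond the scatter. The difference between the core of compound 3 and the core of compound 2 is not broken down here.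

Compound 4, `COc1ccc2nc(NC3CCCCC3)c([S+](C)[O-])nc2c1`, is not yet measured. It arises from compound 3 by a group of 3 heavy atoms (1 carbon, 1 oxygen, 1 sulfur; no ring) in place of a group of 4 heavy atoms (1 carbon, 2 oxygen, 1 sulfur; no ring), on an aromatic carbon. Within the data shown here, this is the same kind of change as the one from compound 2 to compound 1, but the surroundings differ: in compound 1 the group sits on a six-membered aromatic ring of carbon only, para to a large group, whereas in compound 4 it sits on a six-membered aromatic ring with 2 nitrogen, part of a fused system of two rings, next to the ring nitrogen and ortho to a cyclohexylamino group.

Because the earlier step of a 1.3-fold lower number from compound 2 to compound 1 (0.10 log units; within the scatter) lay within the scatter, the step from compound 3 to compound 4 in this assay is expected to be small as well, about a 1.1-fold lower number from compound 3 to compound 4 (0.06 log units; within the scatter). Compound 4 is therefore estimated at 11000 nM, with a range from 5000 nM to 25000 nM.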

Compound 4, half-maximal cytotoxic concentration: 12600 nM
Beside the measured number, compound 4's estimate is 1.1-fold (0.06 log units) below it; the measured number falls inside the stated range.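

In this assay, putting the group of 3 heavy atoms in place of methylsulfonyl on the core of compound 3 gives no change at the digits printed from compound 3 to compound 4 (within the scatter). Set beside the earlier pair on the other core, the swap reads the same on both cores, so in this small set it carries from one core to the other without a step that can be told from the scatter: the same change on two cores in this assay, a 1.3-fold lower number (0.10 log units; within the scatter) from compound 2 to compound 1 and no change at the digits printed (within the scatter) from compound 3 to compound 4, 1.3-fold (0.10 log units) apart, within the scatter of two such steps. Among these compounds, this shows only that neither pair separates the two groups in this assay; it does not show why, and two pairs cannot show that the same would hold on a third core or in any other assay.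

The compounds shown leave open how a methylthio group, a carboxylic acid or an amine would compare in place of methylsulfonyl on either core. They also leave open whether the result would hold with a morpholine or a shorter alkylamine in place of the cyclohexylamino group of compound 4.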